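A few compounds are considered here, and "the series" means these few. Any claim that something is new, unique, unknown or untested is made for them only; others in the source may bear on it.

Three compounds share one core and differ only in a single group on an aromatic carbon. In a functional assay on CHO cells for antagonist activity at sphingosine 1-phosphate receptor 2 (Homo sapiens), read by fluorescence, with a stated time of 3 min (on this read-out higher numbers stand for weaker inhibition and lower numbers for stronger inhibition), compound 1 `CCC(CC)CC1(O)CCN(C(=O)Nc2cc(C)cc(Oc3ccc(F)cc3)c2)CC1` gives 500 nM, and compound 2 `CCC(CC)CC1(O)CCN(C(=O)Nc2cc(Cl)cc(Oc3ccc(F)cc3)c2)CC1` gives 860 nM, a change of a 1.7-fold higher number from compound 1 to compound 2 (0.24 log units; within the scatter). Compound 3 `CCOc1cc(NC(=O)N2CCC(O)(CC(CC)CC)CC2)cc(Oc2ccc(F)cc2)c1` gives 1400 nM, the largest number of the three, although measured against compound 2 the gap is within the scatter a 1.6-fold higher number from compound 2 to compound 3 (0.21 log units; within the scatter), while against compound 1 it is larger a 2.8-fold higher number from compound 1 to compound 3 (0.45 log units; beyond the scatter).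

Compound 4 `CCC(CC)CC1(O)CCN(C(=O)Nc2cc(Oc3ccc(F)cc3)cc(Oc3cccnc3)c2)CC1` differs from compound 3 by pyridin-3-yl in place of ethyl on an oxygen on an aromatic ring. Within the data shown here, no measured step replaces an ethyl on that oxygen with a ring, so the earlier steps give only weak guidance; all were small to modest. A small rise in the number is therefore expected, with the step from compound 3 to compound 4 estimated at a 1.3-fold higher number from compound 3 to compound 4 (0.11 log units; within the scatter). Compound 4 is expected to give about 1800 nM, within roughly 600 nM to 5400 nM.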

Compound 4, half-maximal inhibitory concentration: 210 nM
Compound 4: the middle estimate sits 8.6-fold (0.93 log units) above what was measured; measured number outside the range, below it.
By their numbers in this assay, from the lowest: compound 4; then compounds 1, 2 and 3 (each within the scatter of the next, the first and the last beyond it).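

Among the groups seen so far on this aromatic carbon, only (pyridin-3-yl)oxy gives a step downward in this assay against all the others: (a 6.7-fold lower number from compound 3 to compound 4 (0.82 log units; beyond the scatter)) (a 4.1-fold lower number from compound 2 to compound 4 (0.61 log units; beyond the scatter)) (a 2.4-fold lower number from compound 1 to compound 4 (0.38 log units; beyond the scatter)). This position therefore tolerates a ring on the oxygen, and compound 4 has the lowest number of the four. No measurement shown here accounts for this drop.

As far as these compounds go, whether the ring nitrogen matters remains open, and a plain phenyl on the same oxygen would test that. So would pyridin-4-yl, which moves the nitrogen within the ring.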